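This account rests on a few compounds, and the source may have more. Where it says the series, first, only, none or still open, it means among the compounds named here.

Measured so far in a functional assay on MDA-MB-231 cells (Homo sapiens) for inhibition, read by sulforhodamine B assay, tested at 10 uM; a higher number here means more inhibition at the concentration tested (going by the name of the read-out), a lower number less inhibition:
compound 1 `CN(C)c1ccc(C2CC(c3ccc(-n4cncn4)cc3)=NN2)cc1` — 7%
compound 2 `CN(C)c1ccc(C2CC(c3ccc(-n4cncn4)cc3)=NN2C(=O)c2ccc(F)cc2)cc1` — 12.5%

Compound 2 and compound 1 give numbers within the scatter of each other, so neither stands apart. For the measured compounds named here, the only measured step, a number 5.5 percentage points higher from compound 1 to compound 2 (within the scatter), changes the ring nitrogen substituent and is within the scatter. Compound 3 `CN(C)c1ccc(C2CC(c3ccc(-n4cncn4)cc3)=NN2C(=O)c2ccc(C(F)(F)F)cc2)cc1` differs from compound 2 by trifluoromethyl in place of fluoro on an aromatic carbon. Going by the values given here, no measured step touches this position; the one known step bears on it only by showing that the series so far sits low, with no change beyond the scatter. The step of a number 1.5 percentage points higher from compound 2 to compound 3 (within the scatter) is therefore expected to stay within the scatter. Compound 3 is estimated at 14%, between 0% and 35%.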

Compound 3, a percentage reported as inhibition, at one concentration (the size of the read-out at that concentration, not a potency): 16.7%
Beside the measured number, compound 3's estimate is 2.7 percentage points below it; low and high end bracket the measured number.
By their numbers in this assay, from the lowest: compounds 1, 2 and 3 (each within the scatter of the next).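

In this assay, trifluoromethyl in place of fluoro on the aromatic carbon para to a large group gives a number 4.2 percentage points higher from compound 2 to compound 3 (within the scatter), so this position has not yet shown a change beyond the scatter. The (4-(trifluoromethyl)phenyl)carbonyl group in place of hydrogen on the ring nitrogen gives a number 9.7 percentage points higher from compound 1 to compound 3 (within the scatter), so this group does not separate from hydrogen either. No evidence on what lies behind these small steps is available.

From the compounds shown here alone, whether an amine or a carboxylic acid at this position would give a step beyond the scatter remains open. So does the effect of changes elsewhere on the shared core.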